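A few compounds are considered here, and "the series" means these few. Any claim that something is new, unique, unknown or untested is made for them only; others in the source may bear on it.

Three compounds sharing one core, differing only in the aryl group attached to a carbonyl carbon, have been measured in a functional assay, with a stated time of 30 min; on this read-out higher numbers stand for weaker inhibition and lower numbers for stronger inhibition. Compound 1 `COc1ccc(C2CC(=NOC(=O)c3ccc(Cl)cc3)CC(c3ccc(OC)cc3)N2C)cc1` gives 135000 nM. Compound 2 `COc1ccc(C2CC(=NOC(=O)c3cc([N+](=O)[O-])cc([N+](=O)[O-])c3)CC(c3ccc(OC)cc3)N2C)cc1` gives 312000 nM. Compound 3 `COc1ccc(C2CC(=NOC(=O)c3ccccc3OC(C)=O)CC(c3ccc(OC)cc3)N2C)cc1` gives 350000 nM, the highest of the three numbers, although only its gap to compound 1 lies beyond the scatter: a 2.6-fold higher number from compound 1 to compound 3 (0.41 log units; beyond the scatter), whereas a 1.1-fold higher number from compound 2 to compound 3 (0.05 log units; within the scatter). Compound 4 `COc1ccc(C2CC(=NOC(=O)c3cc(O)c(O)c(O)c3)CC(c3ccc(OC)cc3)N2C)cc1` has not yet been measured. It differs from compound 3 in one place: 3,4,5-trihydroxyphenyl in place of 2-acetoxyphenyl on a carbonyl carbon. Within the data shown here, no measured step involves a trihydroxyphenyl group, so the only guidance is how far changing the aryl group on the carbonyl carbon has moved the numbers so far: a 2.3-fold higher number from compound 1 to compound 2 (0.36 log units; beyond the scatter), and the two steps into compound 3 were modest or within the scatter. The change to compound 4 is therefore expected to be small as well, perhaps a slight move toward a lower number, roughly a 1.3-fold lower number from compound 3 to compound 4 (0.10 log units; within the scatter). In this assay compound 4 is estimated at 280000 nM, with a range from 120000 nM to 650000 nM.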

Compound 4, half-maximal inhibitory concentration: 18000 nM
Estimate against measurement, compound 4: 16-fold (1.19 log units) above; measured number outside the range, below it.
By their numbers in this assay, from the lowest: compound 4; then compound 1; then compounds 2 and 3 (each within the scatter of the next).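

In this assay, among these compounds, the aryl group on the carbonyl carbon can move the number much further than the earlier compounds showed, since 3,4,5-trihydroxyphenyl brings large falls against 2-acetoxyphenyl (a 19-fold lower number from compound 3 to compound 4 (1.29 log units; beyond the scatter)) and against 3,5-dinitrophenyl (a 17-fold lower number from compound 2 to compound 4 (1.24 log units; beyond the scatter)). Among the compounds shown here, it also gives a lower number than 4-chlorophenyl, the group with the lowest earlier number, though by a more modest step (a 7.5-fold lower number from compound 1 to compound 4 (0.88 log units; beyond the scatter)), so this position is not insensitive to change and compound 4 is the only compound here with hydroxyl groups. Nothing measured here explains why this group gives stronger inhibition.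

The compounds shown leave open whether all three hydroxyl groups are needed or whether one or two would give a similar number. They also leave open what an amine or a carboxylic acid on the same ring would do.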